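Chloro Addition on Two Related Purine-Like Cores

The source may report more compounds than this note shows. Statements on the series, on what has been measured and on what is new or still open speak of the compounds shown alone.

Measured so far:
compound 1 `ClCc1ccccc1Cn1cnc2c(Cl)nc(Cl)nc21`: 1820 nM
compound 2 `ClCc1ccccc1Cn1cnc2c(Cl)ncnc21`: 10700 nM
compound 3 `ClCc1ccccc1Cn1cnc2ncnc(Cl)c21`: 5880 nM

The three compounds were tested in a functional assay on UACC-257 cells (Homo sapiens) for cytotoxicity, read by sulforhodamine B assay, with a stated time of 48 h; on this read-out lower numbers stand for stronger inhibition of growth and higher numbers for weaker inhibition of growth. Compound 2 and compound 3 have the same atoms joined differently; the difference between the two cores is not broken down here, and their values stand within the scatter of each other. Compound 1 arises from compound 2 by chloro in place of hydrogen on an aromatic carbon, and this change gave a 5.9-fold lower number from compound 2 to compound 1 (0.77 log units; beyond the scatter).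

Compound 4 `ClCc1ccccc1Cn1cnc2nc(Cl)nc(Cl)c21` is not yet measured. It arises from compound 3 by chloro in place of hydrogen on an aromatic carbon, the same change as that from compound 2 to compound 1, at a place described in identical terms. Because compound 2 to compound 1 gave a 5.9-fold lower number from compound 2 to compound 1 (0.77 log units; beyond the scatter), a step of similar size is expected for compound 4, giving a 4.9-fold lower number from compound 3 to compound 4 (0.69 log units; beyond the scatter). Compound 4 is therefore estimated at 1200 nM, within 500 nM to 3000 nM.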

Compound 4, concentration for 50% growth inhibition: 1990 nM
Beside the measured number, compound 4's estimate is 1.7-fold (0.22 log units) below it; low and high end bracket the measured number.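

In this assay, chloro in place of hydrogen on the aromatic carbon between two ring nitrogen atoms gave a 3.0-fold lower number from compound 3 to compound 4 (0.47 log units; beyond the scatter). The change thus lowered the number on both cores, and the two steps cannot be told apart in size: the same change on two cores in this assay, a 5.9-fold lower number (0.77 log units; beyond the scatter) from compound 2 to compound 1 and a 3.0-fold lower number (0.47 log units; beyond the scatter) from compound 3 to compound 4, 2.0-fold (0.30 log units) apart, within the scatter of two such steps. This shows that the step carried over between these two cores, but it does not show that it would carry to any other core, and it does not explain why the number falls.

The compounds shown leave open whether an amine or a methoxy group on that same carbon would lower the number as chloro does. They also leave open whether the step would hold on other cells.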